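The source may hold more compounds than are shown below. What is called first, only, known or untested is meant among the compounds shown, and "the series" means these compounds.

Measured in a functional assay on MDA-MB-231 cells (Homo sapiens) for antiproliferative activity, read by MTT assay, with a stated time of 72 h; a higher number here means a weaker inhibitor, a lower number a stronger inhibitor:
- compound 1 `O=C(CCc1cccc2c1B(O)OC2)Nc1ccc(Cl)cc1`: 3600 nM
- compound 2 `C#Cc1ccc(NC(=O)CCc2cccc3c2B(O)OC3)cc1`: 6600 nM
- compound 3 `CC(C)(C)OC(=O)Nc1ccc(NC(=O)CCc2cccc3c2B(O)OC3)cc1`: 29000 nM

Compound 3 is the weakest of the three in this assay, at 29000 nM, and its gaps to both other compounds lie beyond the scatter. The next compound, compound 4 `O=C(CCc1cccc2c1B(O)OC2)Nc1ccc(-c2ccccc2)cc1`, keeps the shared core and carries one change: phenyl in place of (tert-butoxycarbonyl)amino on an aromatic carbon.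

For the measured compounds named here, two measured steps bear on this change. They are an 8.1-fold higher number from compound 1 to compound 3 (0.91 log units; beyond the scatter) and a 4.4-fold higher number from compound 2 to compound 3 (0.64 log units; beyond the scatter), and each installs the (tert-butoxycarbonyl)amino group that compound 4 gives up. Both are modest and raise the number. The remaining step, a 1.8-fold higher number from compound 1 to compound 2 (0.26 log units; within the scatter), shows that exchanging chloro for ethynyl leaves the value within the scatter. Going by the values given here, no measured step involves phenyl, so its contribution is unknown and the two steps can only be read in reverse as a rough guide. On that reading, a modest fall in the number is expected, probably not reaching the full size of either step. The expected change is a 3.2-fold lower number from compound 3 to compound 4 (0.51 log units; beyond the scatter). The estimate for compound 4 is 9000 nM, with an expected range of 3000 nM to 26000 nM.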

Compound 4, half-maximal inhibitory concentration: 8800 nM
Compound 4: middle estimate off by 1.0-fold (0.01 log units), on the high side; the range from low to high includes it.
By their numbers in this assay, from the lowest: compounds 1, 2 and 4 (each within the scatter of the next, the first and the last beyond it); then compound 3.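

In this assay, an all-carbon aromatic ring is now shown to be accepted on this aromatic carbon, para to a large group: a 3.3-fold lower number from compound 3 to compound 4 (0.52 log units; beyond the scatter) when phenyl (6 heavy atoms, 0 hydrogen-bond donors) replaces (tert-butoxycarbonyl)amino (8 heavy atoms, 1 hydrogen-bond donor). Group size alone therefore does not set the value here, as the large phenyl group stays within the scatter of the small ethynyl group, a 1.3-fold higher number from compound 2 to compound 4 (0.12 log units; within the scatter), though the gap to chloro lies beyond it, a 2.4-fold higher number from compound 1 to compound 4 (0.39 log units; beyond the scatter). No measured property of these compounds accounts for these differences.

The compounds shown do not separate the parts of the (tert-butoxycarbonyl)amino group, so a free amine or an acetamide on the same carbon would show whether the higher number of compound 3 follows the tert-butyl end or the nitrogen-linked carbonyl. From the compounds shown here alone, how far this position tolerates a further substituted ring also remains open, for example a phenyl carrying methoxy or a carboxylic acid.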